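Swapping One Halophenyl Group for Another

The source may hold more compounds than are shown below. What is called first, only, known or untested is meant among the compounds shown, and "the series" means these compounds.

Of the compounds shown here, three that share one core have been tested in a functional assay on HepG2 cells (Homo sapiens) for inhibition, read by MTT assay, with a stated time of 24 h; on this read-out lower numbers stand for stronger inhibition and higher numbers for weaker inhibition. Compound 1 `CC1(C)[C@H]2CC[C@]1(C)N(Cc1cn(-c3cccc(C#N)c3)nn1)C(=O)C2` gives 40 nM. Compound 2 `CC1(C)[C@H]2CC[C@]1(C)N(Cc1cn(-c3ccccc3F)nn1)C(=O)C2` gives 60 nM, and compound 3 `CC1(C)[C@H]2CC[C@]1(C)N(Cc1cn(-c3cccc(Cl)c3)nn1)C(=O)C2` gives 60 nM. Compound 2 therefore stands level with compound 3, the two sharing the highest number of the three; the gap to compound 1, seen as a 1.5-fold higher number from compound 1 to compound 2 (0.18 log units; within the scatter), lies within the scatter, so no ranking can be drawn from these three.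

Compound 4 `CC1(C)[C@H]2CC[C@]1(C)N(Cc1cn(-c3ccc(Cl)cc3)nn1)C(=O)C2` is the next candidate. Compared with compound 2 it differs by 4-chlorophenyl in place of 2-fluorophenyl on an aromatic nitrogen. For the measured compounds named here, two measured steps bear on this change: the exchange of aryl groups seen in no change at the digits printed from compound 2 to compound 3 (within the scatter), and the exchange of a substituent seen in a 1.5-fold higher number from compound 1 to compound 3 (0.18 log units; within the scatter). Both sit within the scatter, and every step among the measured compounds does the same. Accordingly, no step beyond the scatter is expected in this assay . For compound 4 the expected step is no change at the digits printed from compound 2 to compound 4 (within the scatter). Compound 4 is estimated to give 60 nM, with a range from 25 nM to 150 nM.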

Compound 4, half-maximal inhibitory concentration: 90 nM
The estimate for compound 4 lay 1.5-fold (0.18 log units) below the measured number; the measured number falls inside the stated range.
By their numbers in this assay, from the lowest: compounds 1, 2, 3 and 4 (each within the scatter of the next, the first and the last beyond it).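

In this assay, for the compounds shown here, compound 4 brings the first step in this set that lies beyond the scatter, though a modest one (a 2.3-fold higher number from compound 1 to compound 4 (0.35 log units; beyond the scatter)). Against the two halophenyl compounds, 4-chlorophenyl stays within the scatter (a 1.5-fold higher number from compound 2 to compound 4 (0.18 log units; within the scatter); a 1.5-fold higher number from compound 3 to compound 4 (0.18 log units; within the scatter)), so at this position on the aromatic nitrogen, 4-chlorophenyl can be told apart only from 3-cyanophenyl, and the two chlorophenyl groups cannot be separated by these numbers. No measurement at hand explains the gap between 3-cyanophenyl and 4-chlorophenyl.

On these data alone, it remains open whether 4-cyanophenyl would stand closer to compound 1 or to compound 4, which would help separate the effect of the group from that of its place on the phenyl ring. Also open, as far as these compounds go, is how far the number would move with an amine or a carboxylic acid on that ring, or with a longer chain in place of the ring.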